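This account rests on a few compounds, and the source may have more. Where it says the series, first, only, none or still open, it means among the compounds named here.

Compound 1 `COc1cc(-c2nnc3n2NC(c2ccco2)C(C(=O)c2ccc(Br)cc2)S3)cc(OC)c1OC` is the starting point. In a functional assay on MCF7 cells (Homo sapiens) for cytotoxicity, read by MTT assay, with a stated time of 48 h (on this read-out higher numbers stand for weaker inhibition and lower numbers for stronger inhibition), compound 1 gives > 100000 nM, which is a limit of the assay rather than a number. Compound 2 `COc1ccc(C(=O)C2Sc3nnc(-c4cc(OC)c(OC)c(OC)c4)n3NC2c2cccs2)cc1` is the second measured compound, and in this assay compound 2 gives 49500 nM. Compound 1 therefore stands at the limit of > 100000 nM in this assay, at which 1 of the 2 values shown sits. Compound 3 `COc1cc(-c2nnc3n2NC(c2ccco2)C(C(=O)c2ccc(O)cc2)S3)cc(OC)c1OC` has not yet been measured; it differs from compound 1 by hydroxy in place of bromo on an aromatic carbon. Among the measured compounds shown here, no measured step in this assay covers this change, so only a modest shift, or none beyond the scatter, is expected. Compound 3 is estimated at 80000 nM, between 20000 nM and 300000 nM. The step expected is an at least 1.2-fold lower number from compound 1 to compound 3 (0.09 log units; that floor lies within the scatter).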

Compound 3, half-maximal inhibitory concentration: 88900 nM
Compound 3: middle estimate off by 1.1-fold (0.05 log units), on the low side, and the stated range covers the measured number.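

Putting hydroxy where bromo stood gives an at least 1.1-fold lower number from compound 1 to compound 3 (0.05 log units; that floor lies within the scatter) in this assay. This change at the position on the aromatic ring gives a measured number, though a high one, and on this read-out high numbers stand for weak inhibition. The true size of the step stays unknown, since compound 1 gives only a limit of the assay: the limit of > 100000 nM in this assay, at which 1 of the 3 values shown sits.

Compound 2 differs from compound 1 and compound 3 in more than one place, so it cannot show what this position does alone. Going by these compounds, what an amine or a carboxylic acid would give here remains open.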